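Fluorine Fixed, a Diethylamino Chain Replaces the Ethyl Tail

This account rests on a few compounds, and the source may have more. Where it says the series, first, only, none or still open, it means among the compounds named here.

Compound 1 `CCCCNc1nc(NCc2ccco2)c2ccccc2n1` and compound 2 `CCCCNc1nc(NCc2ccco2)c2cc(F)ccc2n1` were tested in a functional assay on DU-145 cells (Homo sapiens) for cytotoxicity, read by MTT assay, with a stated time of 2 days, tested at 10 uM; on this read-out higher numbers stand for more inhibition at the one concentration tested (going by the name of the read-out) and lower numbers for less inhibition. Compound 1 gives 89.9%, while compound 2 gives 75.4%, the lower of the two numbers. Within the data shown here, the only measured step, a number 14.5 percentage points lower from compound 1 to compound 2 (beyond the scatter), concerns fluoro in place of hydrogen on an aromatic carbon. Compound 3 `CCN(CC)CCNc1nc(NCc2ccco2)c2cc(F)ccc2n1` differs from compound 2 by diethylamino in place of ethyl on a saturated chain carbon, two bonds along the chain from a nitrogen on an aromatic ring. No measured step touches this kind of change, so nothing shown predicts its size or direction. Compound 3 is therefore expected to give about 70%, with a range from 45% to 90%. The step this estimate implies is expected to be a number 5.4 percentage points lower from compound 2 to compound 3 (within the scatter).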

Compound 3, a percentage reported as inhibition, at one concentration (the size of the read-out at that concentration, not a potency): 26.6%
Beside the measured number, compound 3's estimate is 43.4 percentage points above it; measured number below the stated range.
By their numbers in this assay, from the lowest: compound 3; then compound 2; then compound 1.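

In this assay, the chain position proves highly sensitive to this change: replacing ethyl with diethylamino gives a number 48.8 percentage points lower from compound 2 to compound 3 (beyond the scatter). This step far exceeds the earlier fluoro step, a number 14.5 percentage points lower from compound 1 to compound 2 (beyond the scatter), so the chain end matters more here than that ring change. No measurement shown gives a reason for the drop.

Going by these compounds, it remains open whether the drop follows from the added amine or simply from the longer chain, which a dimethylamino end or a plain hexyl chain could help separate. On these data alone, the effect of diethylamino without the fluoro group also remains open.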